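Indole-imidazole series: hydroxyphenyl in place of piperidinyl

A few compounds are considered here, and "the series" means these few. Any claim that something is new, unique, unknown or untested is made for them only; others in the source may bear on it.

Compound 3 `Brc1ccc2[nH]c(-c3cncn3CC3CCCCN3)cc2c1` stands at the weak end of the numbers shown. In an assay on isolated protein for inhibition of Indoleamine 2,3-dioxygenase 1 (Homo sapiens), with a stated time of 1 h (on this read-out lower numbers stand for stronger inhibition and higher numbers for weaker inhibition), compound 3 gives only a limit of the assay, > 100000 nM. Compound 2 `N#Cc1ccc(Cn2cncc2-c2cc3cc(Br)ccc3[nH]2)cc1` gives 3810 nM. Compound 1 `FC(F)(F)c1ccc(Cn2cncc2-c2cc3cc(Br)ccc3[nH]2)cc1` likewise gives only a limit, > 100000 nM. Compound 4 `Oc1cccc(Cn2cncc2-c2cc3cc(Br)ccc3[nH]2)c1` carries 3-hydroxyphenyl in place of piperidin-2-yl on a saturated chain carbon bound to an aromatic nitrogen. Within the data shown here, two measured steps bear on this change: an at least 26-fold higher number from compound 2 to compound 3 (1.41 log units; beyond the scatter), which is the reverse kind of exchange, and an at least 26-fold lower number from compound 1 to compound 2 (1.41 log units; beyond the scatter), which shows that the substituent on the aromatic ring also matters strongly. Returning from piperidin-2-yl to an aromatic ring is therefore expected to bring a large drop in the number for compound 4, an at least 12-fold lower number from compound 3 to compound 4 (1.09 log units; beyond the scatter). For compound 4 in this assay a value of 8000 nM is estimated, with a range from 1500 nM to 50000 nM.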

Compound 4, half-maximal inhibitory concentration: 1600 nM
Estimate against measurement, compound 4: 5.0-fold (0.70 log units) above; the range from low to high includes it.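

In this assay, 3-hydroxyphenyl at this place gives a measurable number where piperidin-2-yl did not: an at least 62-fold lower number from compound 3 to compound 4 (1.79 log units; beyond the scatter). Compound 3 gives only a limit of the assay, > 100000 nM, so this step has a known lower bound but no known full size. Among the aromatic groups, 3-hydroxyphenyl also improves modestly on 4-cyanophenyl: a 2.4-fold lower number from compound 2 to compound 4 (0.38 log units; beyond the scatter).

As far as these compounds go, it remains open how a plain phenyl, a 4-hydroxyphenyl or a 3-aminophenyl would read at this place, and so whether the ring alone or its substituent sets the number.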